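Aryl swap on the ring nitrogen in an inactive series

A few compounds are considered here, and "the series" means these few. Any claim that something is new, unique, unknown or untested is made for them only; others in the source may bear on it.

compound 1 `N#CC1=C(N)Oc2c(N)cc3nc4ccccc4nc3c2C12C(=O)N(Cc1cnnn1-c1ccc(Cl)cc1)c1ccccc12` — compound 1 gives > 50000 nM
compound 2 `COc1ccc(-n2nncc2CN2C(=O)C3(C(C#N)=C(N)Oc4c(N)cc5nc6ccccc6nc5c43)c3ccccc32)cc1` — compound 2 gives > 50000 nM
compound 3 `COc1ccccc1-n1nncc1CN1C(=O)C2(C(C#N)=C(N)Oc3c(N)cc4nc5ccccc5nc4c32)c2ccccc21` — compound 3 gives > 50000 nM

In a functional assay on HCT-116 cells (Homo sapiens) for antiproliferative activity, read by MTT assay, with a stated time of 48 h (a higher number here means a weaker inhibitor, a lower number a stronger inhibitor), compound 3 gives > 50000 nM, which is a limit of the assay and not a number. Compound 1 likewise sits at a limit in this assay. Compound 2 too sits only at a limit there. Compound 3 therefore stands nowhere readable against the others: the steps a step that the two limits leave unreadable from compound 1 to compound 2, a step that the two limits leave unreadable from compound 1 to compound 3 and a step that the two limits leave unreadable from compound 2 to compound 3 cannot be sized, since (the limit of > 50000 nM in this assay, at which 3 of the 3 values shown sit).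

Compound 4 `Cc1ccc(C)c(-n2nncc2CN2C(=O)C3(C(C#N)=C(N)Oc4c(N)cc5nc6ccccc6nc5c43)c3ccccc32)c1` differs from compound 3 by 2,5-dimethylphenyl in place of 2-methoxyphenyl on an aromatic nitrogen. The measured steps that touch the same aryl group on that ring nitrogen, from chloro to methoxy and from one methoxyphenyl to the other, all stayed at the limit, so none of them bears a readable size on this change. No step beyond the scatter is expected in this assay, and the most likely outcome for compound 4 is again a limit rather than a number. Compound 4 is thus expected to give about 60000 nM, with a range from 15000 nM to 250000 nM. This estimate means an expected step that the limit leaves unreadable from compound 3 to compound 4 from compound 3 to compound 4.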

Compound 4, half-maximal inhibitory concentration: > 50000 nM
Compound 4 ended at the assay's limit (the forecaster's own chance of this, stated with the estimate: 85%); the middle value does not contradict the limit.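

Compound 4, like compound 1, compound 2 and compound 3, gives no readable number in this assay, so its steps to those three compounds cannot be read: the limit of > 50000 nM in this assay, at which 4 of the 4 values shown sit. The compounds shown leave open whether any aryl group on that ring nitrogen would bring a value inside the limit.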